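This account rests on a few compounds, and the source may have more. Where it says the series, first, only, none or still open, it means among the compounds named here.

Measured in a functional assay for inhibition of sodium/hydrogen exchanger (Oryctolagus cuniculus); a higher number here means a weaker inhibitor, a lower number a stronger inhibitor:

compound 1, `Cc1c(C(=O)N=C(N)N)cc(S(C)(=O)=O)c(C)c1C`, gives 55 nM
compound 2, `Cc1cc(SC(C)C)c(S(C)(=O)=O)cc1C(=O)N=C(N)N`, gives 12 nM

Of these two, compound 2 stands at the lower number, and its gap to compound 1 lies beyond the usual scatter of this assay. Compound 3, `Cc1cc(Oc2ccc(Cl)cc2)c(S(C)(=O)=O)cc1C(=O)N=C(N)N`, has not yet been measured. It departs from compound 2 in one place: 4-chlorophenoxy in place of isopropylsulfanyl on an aromatic carbon. Going by the values given here, no pair of measured compounds differing in exactly one place is available, so nothing shows how a change at this position moves the number. The entering group is larger than the leaving one, and the two measured compounds give no guide to that. A step of modest size, tending toward a weaker inhibitor, is the expectation for this assay, and it is expected to be a 2.1-fold higher number from compound 2 to compound 3 (0.32 log units; beyond the scatter). Compound 3 is therefore estimated at 25 nM, within a range of 6 nM to 100 nM.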

Compound 3, half-maximal inhibitory concentration: 13 nM
Beside the measured number, compound 3's estimate is 1.9-fold (0.28 log units) above it; low and high end bracket the measured number.
By their numbers in this assay, from the lowest: compounds 2 and 3 (each within the scatter of the next); then compound 1.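

In this assay, swapping in 4-chlorophenoxy gives a 1.1-fold higher number from compound 2 to compound 3 (0.03 log units; within the scatter), so the two numbers cannot be told apart. This position on the aromatic carbon therefore accepts a group of 8 heavy atoms carrying a six-membered aromatic ring as readily as the 4-atom isopropylsulfanyl chain with no ring, at least in this one pair. No measurement shown here accounts for this result.

The compounds shown leave open whether a much smaller group at this position, such as methoxy, or a charged one, such as an amine or a carboxylic acid, would keep the number in the same range. They also leave open what the chlorine contributes, a question that plain phenoxy could address.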